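The source may report more compounds than this note shows. Statements on the series, on what has been measured and on what is new or still open speak of the compounds shown alone.

For the measured compounds named here, in a functional assay on MCF7 cells (Homo sapiens) for antiproliferative activity, with a stated time of 96 h (a higher number here means a weaker inhibitor, a lower number a stronger inhibitor), compound 1 (`Cc1cc(=O)oc2cc(OCC(=O)c3ccc(C(C)(C)C)cc3)ccc12`) gives 20700 nM, the only actual number in this small set. Compound 2 (`CC(C)(C)c1ccc(C(=O)COc2ccc3c(C(F)(F)F)cc(=O)oc3c2)cc1`) has no number at all and is recorded as "not active" (no number reported). Compound 3 (`O=C(COc1ccc2c(C(F)(F)F)cc(=O)oc2c1)c1ccccc1C(F)(F)F`) is the one further entry without a number, and it too is recorded as "not active" (no number reported). Compound 2 therefore cannot be placed on a scale, and the measurements show only that it gave no reported potency in this assay.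

Compound 4 (`O=C(COc1ccc2c(C(F)(F)F)cc(=O)oc2c1)c1ccc(F)cc1`) has not yet been measured. Its structural change from compound 2 is fluoro in place of tert-butyl on an aromatic carbon, with fluoro in place of tert-butyl on an aromatic carbon, para to a large group.

Going by the values given here, no measured pair here shows what a single change does, and compound 2 offers no number to start from, so the size of the step cannot be calculated. The expectation is therefore modest: at best a small move towards stronger inhibition in this assay, with compound 4 landing in the same weak range as compound 1 at 20700 nM. A result with no number is at least as likely, as seen for compound 3 at "not active" (no number reported).

If a number is reported, the estimate for compound 4 is 30000 nM, with an expected range from 10000 nM to 80000 nM.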

Compound 4, half-maximal inhibitory concentration: "not active" (no number reported)
Nothing numeric was reported for compound 4; no gap can be computed for the estimate.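

Compound 2 and compound 4 are both recorded in this assay without a number, so no step can be read for fluoro in place of tert-butyl. No measurement shown here offers an explanation for this result. Going by these compounds, whether that change alters antiproliferative potency at all, and by how much, remains open.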